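A Much Smaller Group on the Amide-Type Nitrogen

The compounds below may be only part of what the source reports. "The series", "measured", "known", "first", "only" and "open" are said of these compounds alone.

In a functional assay on HeLa cells (Homo sapiens) for inhibition, read by MTT assay, with a stated time of 4 days (a lower number here means a stronger inhibitor, a higher number a weaker inhibitor), compound 1 (`COc1ccc(C(=NNC(=O)NNC(=O)NCCCC(C)Nc2cc(OC)cc3cccnc23)c2ccc(OC)cc2)cc1`) gives 50000 nM and compound 2 (`COc1cc(NC(C)CCCNC(=O)NNC(=O)Nc2ccc(Cl)c(C(F)(F)F)c2)c2ncccc2c1`) gives 17000 nM as the lower of the two numbers. That gap lies beyond the usual scatter, so compound 2 is the stronger inhibitor of this pair. Compound 3 (`COc1cc(NC(C)CCCNC(=O)NNC(=O)NCCO)c2ncccc2c1`) has not been measured yet. It differs from compound 2 in one place (2-hydroxyethyl in place of 4-chloro-3-(trifluoromethyl)phenyl on an amide-type nitrogen), with 2-hydroxyethyl in place of 4-chloro-3-(trifluoromethyl)phenyl on an amide-type nitrogen. For the measured compounds named here, no measured compound carries 2-hydroxyethyl, so the only guides are the size of this change and compound 2 at 17000 nM as the starting point. In this assay a weaker result is expected, with a 2.9-fold higher number from compound 2 to compound 3 (0.47 log units; beyond the scatter) as the estimated step, although this expectation is loose. Compound 3 is estimated at 50000 nM with 17000 nM to 150000 nM as the expected range.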

Compound 3, half-maximal inhibitory concentration: 196000 nM
Estimate against measurement, compound 3: 3.9-fold (0.59 log units) below; measured number outside the range, above it.
By their numbers in this assay, from the lowest: compound 2; then compound 1; then compound 3.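

For the compounds shown here, replacing the 4-chloro-3-(trifluoromethyl)phenyl with 2-hydroxyethyl on this amide-type nitrogen gives a 12-fold higher number from compound 2 to compound 3 (1.06 log units; beyond the scatter) in this assay, the first change at a single place in this set. It shows that the group on this nitrogen matters in this assay, and that the small 2-hydroxyethyl is much less favourable here than the larger aromatic group. No data shown here give a reason for this step.

The change removes the aromatic ring, its chlorine and its trifluoromethyl, and adds a hydroxyl, all at once, so the compounds shown cannot separate the contribution of each. As far as these compounds go, a plain phenyl would test the ring without its chlorine and trifluoromethyl, and a plain ethyl would test the short chain without its hydroxyl; how either would compare remains open.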